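The compounds below may be only part of what the source reports. "The series", "measured", "known", "first", "only" and "open" are said of these compounds alone.

Values in a physicochemical assay for lipophilicity, measured as chromatographic lipophilicity, at pH 7.4 (on this read-out lower numbers stand for lower lipophilicity and higher numbers for higher lipophilicity), for the measured compounds:

Compound 1 `COc1cc(-c2nnc3n2CCCC3(O)c2ccc(Cl)c(Cl)c2)ccc1-c1cnc(C)o1` gives 2.9
Compound 2 `COc1cc(-c2nnc3n2CCCC3(c2ccc(Cl)c(Cl)c2)C(C)(C)O)ccc1-c1cnc(C)o1` gives 3.7
Compound 3 `COc1cc(-c2nnc3n2CCCC3(Oc2ccc(F)c(F)c2)C(C)(C)O)ccc1-c1cnc(C)o1` gives 2.8

Among these three, compound 2 stands highest at 3.7, and the other two lie clearly lower. Compound 4 `COc1cc(-c2nnc3n2CCCC3(Oc2ccc(F)c(Cl)c2)C(C)(C)O)ccc1-c1cnc(C)o1` has not yet been measured. It carries 3-chloro-4-fluorophenoxy in place of 3,4-dichlorophenyl on a saturated ring carbon of compound 2 (3-chloro-4-fluorophenoxy in place of 3,4-dichlorophenyl on a saturated ring carbon).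

The closest evidence is the modest fall a number 0.90 log units lower from compound 2 to compound 3 (beyond the scatter), where 3,4-difluorophenoxy enters at the same carbon. For the measured compounds named here, compound 4 differs from compound 3 by keeping one chlorine in place of a fluorine, so a smaller fall than that is expected, though the data hold no measured step for that exchange alone. The modest rise a number 0.80 log units higher from compound 1 to compound 2 (beyond the scatter) concerns 1-hydroxy-1-methylethyl in place of hydroxy, a group that does not change here, so it offers little guidance.

The expected change is a modest fall a number 0.40 log units lower from compound 2 to compound 4 (beyond the scatter). Compound 4 is estimated at 3.3, with an expected range from 3 to 3.6.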

Compound 4, distribution coefficient: 3.2
The estimate for compound 4 lay 0.10 log units above the measured number; the range from low to high includes it.
By their numbers in this assay, from the lowest: compounds 3, 1 and 4 (each within the scatter of the next, the first and the last beyond it); then compound 2.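

In this assay, 3-chloro-4-fluorophenoxy in place of 3,4-dichlorophenyl on the saturated ring carbon gives a number 0.50 log units lower from compound 2 to compound 4 (beyond the scatter), so both phenoxy compounds shown lie below compound 2, with no compound here going against that. Exchanging a single fluoro for chloro on an aromatic carbon of the phenoxy group gives a number 0.40 log units higher from compound 3 to compound 4 (beyond the scatter), which shows that this one halogen alone moves the number beyond the scatter. No measurement on hand accounts for either step.

From the compounds shown here alone, it remains open how much of the fall from compound 2 belongs to the ether oxygen and how much to the halogens, a question that 3,4-dichlorophenoxy at this carbon would address. Going by these compounds, the effect of an amine or a longer chain in place of 1-hydroxy-1-methylethyl also remains open.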